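Swapping a difluoromethoxy for a carbamoyl group

This account rests on a few compounds, and the source may have more. Where it says the series, first, only, none or still open, it means among the compounds named here.

Measured so far in a functional assay on CHO cells for agonist activity at Alpha-1A adrenergic receptor (Homo sapiens), read by FLIPR and calcium flux; on this read-out higher numbers stand for an effect only at larger amounts of compound and lower numbers for an effect already at smaller amounts:
- compound 1, `FC(F)Oc1ccccc1C1Cc2nccn2C1`: 11 nM
- compound 2, `Clc1ccccc1C1CCc2nc[nH]c2C1`: 276 nM
- compound 3, `COCc1ccccc1C1CCc2nc[nH]c2C1`: 76 nM; 48 nM (2 entries)

Of the two compounds with a single number, compound 1 has the lower one; compound 2 sits far above it, well beyond the scatter. Compound 3 was run more than once, and its two entries the several entries of compound 3 in this assay, 76 nM; 48 nM (2 entries) lie within the scatter of each other, so it gives no single number to rank against. Within the data shown here, compounds 2 and 3 share a core different from that of compound 1, so no direct step links them to it.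

Among the measured compounds shown here, the new compound, compound 4, `NC(=O)c1ccccc1C1Cc2nccn2C1`, keeps the core of compound 1 and changes only one group: carbamoyl in place of difluoromethoxy on an aromatic carbon. For the measured compounds named here, no measured pair shows this change, so the expected size of the step comes from the change itself. Compound 4 is expected to give a somewhat higher number than compound 1, a modest loss rather than none, with the step from compound 1 to compound 4 estimated at a 3.2-fold higher number from compound 1 to compound 4 (0.50 log units; beyond the scatter). Compound 4 is thus estimated at 35 nM, in a range from 8 nM to 150 nM.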

Compound 4, half-maximal effective concentration: 371 nM
Compound 4: the middle estimate sits 11-fold (1.03 log units) below what was measured, outside the stated range (above it).
By their numbers in this assay, from the lowest: compound 1; then compounds 2 and 4 (each within the scatter of the next).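

In this assay, putting carbamoyl in place of difluoromethoxy on this aromatic carbon, ortho to a group of 8 heavy atoms, gives a 34-fold higher number from compound 1 to compound 4 (1.53 log units; beyond the scatter) on an otherwise unchanged structure. This is the first change in one place among these compounds, and it shows that the group at this position strongly affects the read-out, with a large step from a swap of only a few atoms. Nothing measured here bears on why this step is so large.

The compounds shown leave open how other groups on this aromatic carbon, such as a methoxy, a nitrile or a methyl ester, would behave on the core of compound 1. They also leave open whether the same swap would give a step of similar size on the different core of compound 2 and compound 3.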